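Chlorophenyl in place of cyanomethylphenyl on the piperazine

This account rests on a few compounds, and the source may have more. Where it says the series, first, only, none or still open, it means among the compounds named here.

Compound 2 `Cc1cc(N2CCN(C(=O)[C@H]3NCC4(CC4)C[C@@H]3C(=O)NO)CC2)ccc1C#N` carries a 4-cyano-3-methylphenyl on an amine nitrogen in a ring. In an assay on isolated protein for binding affinity to disintegrin and metalloproteinase domain-containing protein 10 (Homo sapiens) (a higher number here means a weaker inhibitor, a lower number a stronger inhibitor), compound 2 gives 38 nM. Its only companion, compound 1 `COc1cccc(C2=CCN(C(=O)[C@H]3NCC4(CC4)C[C@@H]3C(=O)NO)CC2)c1`, gives 40 nM in this assay; the two numbers lie within the scatter of each other, so compound 2 stands level with compound 1 rather than apart from it. Compound 3 `O=C(NO)[C@H]1CC2(CC2)CN[C@@H]1C(=O)N1CCN(c2cccc(Cl)c2)CC1` differs from compound 2 in one place: 3-chlorophenyl in place of 4-cyano-3-methylphenyl on an amine nitrogen in a ring. Among the compounds with values here, no step between measured compounds shows how this aryl group on the ring nitrogen matters. A step of modest size at most is expected, because compound 1 with its 3-methoxyphenyl gives 40 nM, no different from compound 2. Compound 3 is therefore expected to give about 55 nM in this assay, in the range 15 nM to 200 nM. The step of a 1.4-fold higher number from compound 2 to compound 3 (0.16 log units; within the scatter) is thus estimated to stay near the scatter.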

Compound 3, half-maximal inhibitory concentration: 14 nM
The estimate for compound 3 lay 3.9-fold (0.59 log units) above the measured number; measured number below the stated range.
By their numbers in this assay, from the lowest: compound 3; then compounds 2 and 1 (each within the scatter of the next).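

In this assay, the aryl group on the amine nitrogen in the ring proves able to shift the number: 3-chlorophenyl in place of 4-cyano-3-methylphenyl gives a 2.7-fold lower number from compound 2 to compound 3 (0.43 log units; beyond the scatter). The step is modest but beyond the scatter, and it shows that neither the nitrile nor the methyl group is needed on this aryl ring for a number at this level. Nothing measured here bears on the reason for this step.

This single exchange removes the nitrile and the methyl group and brings in chlorine all at once, so the share of each change in the step cannot be separated. From the compounds shown here alone, it also remains open whether a bromine or a trifluoromethyl group in place of the chlorine would keep, lower or raise the number.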